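The compounds below may be only part of what the source reports. "The series", "measured", "known", "first", "only" and "open" are said of these compounds alone.

Measured in a physicochemical assay for solubility; on this read-out lower numbers stand for lower solubility and higher numbers for higher solubility:
- compound 1 `O=S(=O)(Nc1nccs1)c1ccc2c(c1)OCC[C@@H]2c1ccc(C(F)(F)F)cc1-c1ccc(F)cc1`: 39000 nM
- compound 2 `O=S(=O)(Nc1nccs1)c1ccc2c(c1)OCC[C@H]2c1ccc(C(F)(F)F)cc1-c1ccc(F)cc1`: 147000 nM

Of the two, compound 1 has the lower number. Compound 3 `O=S(=O)(Nc1nccs1)c1ccc2c(c1)OCC[C@@H]2c1ccc(C(F)(F)F)cc1-c1nccs1` has 1,3-thiazol-2-yl in place of 4-fluorophenyl on an aromatic carbon. Among the compounds with values here, the only measured step, a 3.8-fold higher number from compound 1 to compound 2 (0.58 log units; beyond the scatter), rests on (the fact that compounds 1 and 2 differ only in the configuration as drawn). It leaves this group untouched, so it bears on the exchange only as a guide to size. A modest move towards a higher number in this assay is expected, with the estimated step being a 2.3-fold higher number from compound 1 to compound 3 (0.36 log units; beyond the scatter). Compound 3 is estimated at 90000 nM, with an expected range of 30000 nM to 260000 nM.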

Compound 3, solubility: 15000 nM
Compound 3: the middle estimate sits 6.0-fold (0.78 log units) above what was measured, and the stated range ends above it.
By their numbers in this assay, from the lowest: compound 3; then compound 1; then compound 2.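

The aromatic carbon ortho to a large group responds in this assay: 1,3-thiazol-2-yl in place of 4-fluorophenyl gives a 2.6-fold lower number from compound 1 to compound 3 (0.41 log units; beyond the scatter), opposite in direction to a 3.8-fold higher number from compound 1 to compound 2 (0.58 log units; beyond the scatter). So the number depends on this aryl position as well as on the configuration of the stereocentre. Nothing at hand accounts for the direction of this exchange.

Open, on these data alone, is whether an amine or a carboxylic acid at this position would raise the number. Also open, as far as these compounds go, is whether the same exchange gives a similar step in the configuration of compound 2.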